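Aryl exchange on the saturated ring carbon: compound 4

A few compounds are considered here, and "the series" means these few. Any claim that something is new, unique, unknown or untested is made for them only; others in the source may bear on it.

Measured in an assay on HEK293 cells for antagonist activity at transient receptor potential M8 protein (Canis lupus familiaris), read by fluorescence and calcium flux, with a stated time of 5 min; a higher number here means a weaker inhibitor, a lower number a stronger inhibitor:
compound 1 `O=C(C(Nc1ccccc1)c1ccc(C(F)(F)F)cc1)N1CCCC1c1ccccc1` gives 60 nM;
compound 2 `COc1ccccc1C1CCCN1C(=O)C(Nc1ccccc1)c1ccc(C(F)(F)F)cc1` gives 33 nM;
compound 3 `O=C(C(Nc1ccccc1F)c1ccc(C(F)(F)F)cc1)N1CCCC1c1ccc(F)cc1` gives 37 nM.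

Compound 3 sits second highest of the three numbers, nearest to compound 2 and furthest from compound 1, both gaps within the scatter. Compound 4 `COc1ccccc1C1CCCN1C(=O)C(Nc1ccccc1F)c1ccc(C(F)(F)F)cc1` differs from compound 3 by 2-methoxyphenyl in place of 4-fluorophenyl on a saturated ring carbon. Among the compounds with values here, the only measured step on this ring carbon is a 1.8-fold lower number from compound 1 to compound 2 (0.26 log units; within the scatter), where a methoxy was added on the aromatic ring there; it stayed within the scatter. Within the data shown here, the 4-fluorophenyl to 2-methoxyphenyl exchange in compound 4 has no direct precedent, but since compound 2 and compound 3 read alike in this assay, no step beyond the scatter is expected, a 1.2-fold lower number from compound 3 to compound 4 (0.09 log units; within the scatter). Compound 4 is therefore estimated at 30 nM, between 12 nM and 80 nM.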

Compound 4, half-maximal inhibitory concentration: 12 nM
Beside the measured number, compound 4's estimate is 2.5-fold (0.40 log units) above it, within the range that was stated.
By their numbers in this assay, from the lowest: compound 4; then compounds 2, 3 and 1 (each within the scatter of the next).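

In this assay, within the data shown here, 2-methoxyphenyl in place of 4-fluorophenyl on the saturated ring carbon gives a 3.1-fold lower number from compound 3 to compound 4 (0.49 log units; beyond the scatter) and is the first step at this carbon beyond the scatter, since the earlier one stayed within it. Fluoro in place of hydrogen on an aromatic carbon gives a 2.8-fold lower number from compound 2 to compound 4 (0.44 log units; beyond the scatter) with 2-methoxyphenyl held fixed, so a second place in the series also moves the number. Nothing available explains either step.

On these data alone, whether an ethoxy or a dimethylamino group in place of the methoxy keeps the number of compound 4 remains open.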